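The compounds below may be only part of what the source reports. "The series", "measured", "known", "first", "only" and "open" are said of these compounds alone.

Compound 2 `COc1ccc(C(=O)CSc2nnc(-c3cc(OC)c(OC)c(OC)c3)n2-c2ccc(OC)cc2)cc1` gives in a functional assay on HT-29 cells (Homo sapiens) for inhibition, read by MTT assay, with a stated time of 48 h (on this read-out higher numbers stand for weaker inhibition and lower numbers for stronger inhibition), only a limit, > 60000 nM. Compound 1 `COc1ccc(-n2c(SCc3ccc(C)cc3)nnc2-c2cc(OC)c(OC)c(OC)c2)cc1` likewise gives only a limit in this assay, > 60000 nM. The step that the two limits leave unreadable from compound 1 to compound 2 is therefore unreadable, both values sitting at the limit of > 60000 nM in this assay, at which 2 of the 2 values shown sit. Compound 3 `COc1ccc(C(=O)CSc2nnc(-c3cc(OC)c(OC)c(OC)c3)n2-c2ccc(N(C)C)cc2)cc1` differs from compound 2 by dimethylamino in place of methoxy on an aromatic carbon. Among the measured compounds shown here, no measured step bears on this change, since the one recorded step is unreadable. With compound 2 standing at a limit, the step of a number no higher from compound 2 to compound 3 (the limit leaves the size open) is expected to amount to nothing beyond the scatter. Compound 3 is estimated at 60000 nM, within 15000 nM to 200000 nM, and is expected to be reported again only as a limit.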

Compound 3, half-maximal inhibitory concentration: 64000 nM
The estimate for compound 3 lay 1.1-fold (0.03 log units) below the measured number; low and high end bracket the measured number.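

In this assay, among the compounds shown here, compound 2 gives only a limit, > 60000 nM, so no step to compound 3 can be read. The compounds shown leave open whether dimethylamino in place of methoxy on an aromatic carbon alters inhibition at all.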